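Replacing the Anilide Methoxy with a Phenyl Group

The source may report more compounds than this note shows. Statements on the series, on what has been measured and on what is new or still open speak of the compounds shown alone.

Compound 1 `O=C(COc1ccc2c(=O)cc(-c3ccccc3)oc2c1)Nc1ccccc1`: > 10000 nM
Compound 2 `COc1ccc(NC(=O)COc2ccc3c(=O)cc(-c4ccccc4)oc3c2)cc1`: 5500 nM

Compound 1 reaches only a limit in a functional assay on NCI-H661 cells (Homo sapiens) for antiproliferative activity, read by MTT assay, with a stated time of 72 h (on this read-out lower numbers stand for stronger inhibition of growth and higher numbers for weaker inhibition of growth), giving > 10000 nM. Among the measured compounds shown here, compound 2 is the one compound with a number in this assay, where compound 2 gives 5500 nM. The step of an at least 1.8-fold lower number from compound 1 to compound 2 (0.25 log units; that floor lies within the scatter) is the only measured one and rests on a limit (the limit of > 10000 nM in this assay, at which 1 of the 2 values shown sits). Compound 3 `O=C(COc1ccc2c(=O)cc(-c3ccccc3)oc2c1)Nc1ccc(-c2ccccc2)cc1` differs from compound 2 by phenyl in place of methoxy on an aromatic carbon. For the measured compounds named here, no measured step covers a phenyl entering here, so the step of a 1.2-fold lower number from compound 2 to compound 3 (0.09 log units; within the scatter) is expected to stay within the scatter. Compound 3 is estimated at 4500 nM, within 1500 nM to 15000 nM.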

Compound 3, concentration for 50% growth inhibition: 1280 nM
For compound 3 the middle estimate is 3.5-fold (0.55 log units) above the measured one, outside the stated range (below it).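

At this aromatic carbon, para to a large group, phenyl brings what methoxy did not show, a change beyond the scatter in this assay: a 4.3-fold lower number from compound 2 to compound 3 (0.63 log units; beyond the scatter). Compound 1 gives only a limit, so an at least 7.8-fold lower number from compound 1 to compound 3 (0.89 log units; beyond the scatter) is a floor, though it already lies beyond the scatter: the limit of > 10000 nM in this assay, at which 1 of the 3 values shown sits.

The compounds shown leave open whether this carbon needs an aromatic ring, or whether a cyclohexyl ring or a longer chain would serve as well. They also leave open how an amine or a carboxylic acid would fare there.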